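From compound 2 to compound 4: oxirane ring removed

The source may report more compounds than this note shows. Statements on the series, on what has been measured and on what is new or still open speak of the compounds shown alone.

Values so far in a functional assay on HepG2 cells (Homo sapiens) for cytotoxicity, with a stated time of 72 h; on this read-out higher numbers stand for an effect only at larger amounts of compound and lower numbers for an effect already at smaller amounts

- Compound 1 `C=C[C@@](C)(/C=C/c1ccc(OS(=O)(=O)C(F)(F)F)cc1)CCC=C(C)C` gives > 52000 nM
- Compound 2 `C=C[C@@](C)(/C=C/c1ccc(O)cc1)CCC1OC1(C)C` gives > 52000 nM
- Compound 3 `C=C[C@@](C)(/C=C/c1ccc(O)cc1)CC/C=C/C(=O)OCc1ccccc1` gives > 52000 nM

Each of these entries is a limit of the assay and not a number. Compound 2 has only the limit > 52000 nM. It is not alone there: the limit of > 52000 nM in this assay, at which 3 of the 3 values shown sit.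

Compound 4 `C=C[C@@](C)(/C=C/c1ccc(O)cc1)CC/C=C(\C)CO` has the same atoms as compound 2, joined differently: 2-(hydroxymethyl)prop-1-en-1-yl in place of 3,3-dimethyloxiran-2-yl on a saturated chain carbon, three bonds along the chain from two double-bonded chain carbons. The three-membered ring is gone, and a chain with a double bond and a hydroxymethyl group stands in its place.

Going by the values given here, no measured pair shows what a single change does in this assay, so the size of this step cannot be read from the data. Compounds 1, 2 and 3 differ from one another in structure, yet (the limit of > 52000 nM in this assay, at which 3 of the 3 values shown sit). On that basis, no shift beyond the scatter is expected in this assay, and compound 4 is expected to reach the same limit. The expected change is a number no higher from compound 2 to compound 4 (the limit leaves the size open). For compound 4 the estimated value is 52000 nM, with an expected range of 30000 nM to 100000 nM.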

Compound 4, half-maximal effective concentration: > 52000 nM
Compound 4: only a limit was reported (the forecaster's own chance of this, stated with the estimate: 85%); the middle value lies on the limit itself.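

In this assay, compound 2 and compound 4 both stop at a limit rather than a number, so no step between them can be read: the limit of > 52000 nM in this assay, at which 4 of the 4 values shown sit.

On these data alone, how far past that limit each compound lies stays open, as does which structural change, if any, would give a measurable value.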